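The source may report more compounds than this note shows. Statements on the series, on what has been measured and on what is new or still open speak of the compounds shown alone.

Measured compounds:
- compound 1, `C=C1CCCC(C)(C)C1CC[C@]1(C)CC[C@@H]([C@@H](C)C(=O)O)OO1`: 9540 nM
- compound 2, `C=C1CCC[C@H]2[C@](C)(CC[C@]3(C)CC[C@@H]([C@@H](C)C(=O)O)OO3)[C@@H](C)CC[C@]12C`: 1040 nM

In a functional assay on HOP-62 cells (Homo sapiens) for inhibition (a higher number here means a weaker inhibitor of growth, a lower number a stronger inhibitor of growth), compound 2 gives 1040 nM, the lowest of the two numbers; compound 1 gives 9540 nM, a gap beyond the scatter. Compound 3, `C=C1CCC[C@H]2[C@](C)(CC[C@]3(C)CC[C@H]([C@@H](C)C(=O)O)OO3)[C@@H](C)CC[C@]12C`, is not yet measured. Its relation to compound 2: the two compounds have the same atoms and bonds and differ only in configuration as drawn: 1 of 7 stereo elements differ; a stereocentre at a saturated ring carbon is drawn S in compound 2 and R in compound 3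

Among the compounds with values here, no step between measured compounds isolates a change in configuration, so the size of the step is unknown. A change of this kind could go either way; the expected step from compound 2 to compound 3 is a 1.5-fold higher number from compound 2 to compound 3 (0.19 log units; within the scatter), a slight weakening not clearly beyond the scatter. Compound 3 is thus estimated at 1600 nM, with a range from 500 nM to 6000 nM.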

Compound 3, concentration for 50% growth inhibition: 1050 nM
Beside the measured number, compound 3's estimate is 1.5-fold (0.18 log units) above it; measured number inside the range.
By their numbers in this assay, from the lowest: compounds 2 and 3 (each within the scatter of the next); then compound 1.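

In this assay inverting the stereocentre at a saturated ring carbon gives a 1.0-fold higher number from compound 2 to compound 3 (0.00 log units; within the scatter) and so, at this position, S and R cannot be told apart in this read-out. This is the first step in the series to isolate a single change of configuration, and the comparison involves no other structural difference: the fact that compounds 2 and 3 differ only in the configuration as drawn

Going by these compounds, whether the same holds for the other stereo elements, or for this stereocentre on the core of compound 1, stays open. So does the outcome of replacing the carboxylic acid with a methyl ester or an amide.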